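Spiro-amine variants of a nitro core: cytotoxicity notes

The source may report more compounds than this note shows. Statements on the series, on what has been measured and on what is new or still open speak of the compounds shown alone.

In an ADME assay on Vero cells (Chlorocebus sabaeus) for cytotoxicity, read by MTT assay, with a stated time of 72 h (on this read-out higher numbers stand for lower toxicity in this test and lower numbers for higher toxicity in this test), compound 1 `O=c1nc(N2CCN(CC3CCCCC3)CC2)sc2c([N+](=O)[O-])cc(C(F)(F)F)cc12` gives 1400000 nM. Compound 2 `O=c1nc(N2CCC3(CCN(Cc4ccccc4)C3)CC2)sc2c([N+](=O)[O-])cc(C(F)(F)F)cc12` gives 289000 nM in this assay, the lowest of the two numbers, with compound 1 the nearer value and its gap beyond the scatter. Compound 3 `CCOC(=O)CN1CCC2(CCN(c3nc(=O)c4cc(C(F)(F)F)cc([N+](=O)[O-])c4s3)CC2)C1` carries ethoxycarbonyl in place of phenyl on a saturated chain carbon bound to an amine nitrogen in a ring. Within the data shown here, no step between measured compounds covers this change, so the direction is open; a modest rise toward compound 1 is expected, a 1.6-fold higher number from compound 2 to compound 3 (0.19 log units; within the scatter), though a result within the scatter of compound 2 would not surprise. Compound 3 is therefore estimated at 450000 nM in this assay, with a range from 150000 nM to 1300000 nM.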

Compound 3, half-maximal cytotoxic concentration in the Vero assay: 266000 nM
Compound 3: middle estimate off by 1.7-fold (0.23 log units), on the high side, within the range that was stated.
By their numbers in the Vero assay, from the lowest: compounds 3 and 2 (each within the scatter of the next); then compound 1.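

In the Vero assay ethoxycarbonyl in place of phenyl on a saturated chain carbon bound to an amine nitrogen in a ring gives a 1.1-fold lower number from compound 2 to compound 3 (0.04 log units; within the scatter) and so the read-out does not separate these two groups at this position. In a physicochemical assay for solubility, read by HPLC, with a stated time of 12 h, at pH 2 (a lower number here means a less soluble compound, a higher number a more soluble compound), compound 2 gives 1.56 ug/mL and compound 3 gives 2.04 ug/mL with a 1.3-fold higher number from compound 2 to compound 3 (0.12 log units; within the scatter) and so this read-out does not separate them either. Nothing available here accounts for these results. As far as these compounds go, whether a carboxylic acid or an amine in place of ethoxycarbonyl would stay within the scatter of these two compounds in either read-out remains open.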